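The compounds below may be only part of what the source reports. "The series", "measured", "known", "first", "only" and "open" are said of these compounds alone.

Compound 1 `C=CCCn1c(=O)c2[nH]cnc2n(CCC)c1=O` is a small molecule that in an assay on Cerebral cortex for binding affinity to adenosine receptor A1 (Cavia porcellus), read by radioligand binding (a higher number here means a weaker inhibitor, a lower number a stronger inhibitor), gives 60 nM. Compound 2 `CCCn1c(=O)n(CCC(=O)O)c(=O)c2[nH]cnc21` differs from it in one place, (carboxy in place of vinyl on a saturated chain carbon, two bonds along the chain from an aromatic nitrogen). For compound 2 this assay returns only a limit, > 200000 nM, not a number. That one change produced an at least 3300-fold higher number from compound 1 to compound 2 (3.52 log units; beyond the scatter), a step that ends at the limit of > 200000 nM in this assay, at which 1 of the 3 values shown sits.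

Compound 3 `C=CCCn1cnc2c1c(=O)n(C)c(=O)n2CCC` has a different core; how its core differs from that of compound 1 is not broken down here. In this assay compound 3 gives 6000 nM.

Compound 4 `CCCn1c(=O)n(C)c(=O)c2c1ncn2CCC(=O)O`, not yet measured, stands to compound 3 as compound 2 stands to compound 1: carboxy in place of vinyl on a saturated chain carbon, two bonds along the chain from an aromatic nitrogen, the same change at the same kind of place. Because the earlier change gave an at least 3300-fold higher number from compound 1 to compound 2 (3.52 log units; beyond the scatter), the step is expected to be a 330-fold higher number from compound 3 to compound 4 (2.52 log units; beyond the scatter). For compound 4 the estimated result is 2000000 nM, most likely again reported only as a limit.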

Compound 4, inhibition constant: > 200000 nM
Compound 4: only a limit was reported; the forecaster's own chance of this, stated with the estimate: 90%; the middle value lies beyond the limit too.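

On the core of compound 3, carboxy in place of vinyl again weakens binding sharply in this assay, with an at least 33-fold higher number from compound 3 to compound 4 (1.52 log units; beyond the scatter). Compound 4 gives only a limit, > 200000 nM, not a number. The direction of the change therefore carries over between these two cores, but how far its size carries over stays unknown: the same change on two cores in this assay, an at least 3300-fold higher number (3.52 log units; beyond the scatter) from compound 1 to compound 2 and an at least 33-fold higher number (1.52 log units; beyond the scatter) from compound 3 to compound 4; the limit leaves it open whether they differ

The compounds shown leave open whether an ester or an amide in place of carboxy, or a longer chain ending in a carboxylic acid, would bring the result back to a measurable number in this assay. They also leave open whether the same change acts in the same direction on any core beyond these two.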